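Swapping methyl for chloro on a pyridyl ether

The compounds below may be only part of what the source reports. "The series", "measured", "known", "first", "only" and "open" are said of these compounds alone.

Measured compounds:
compound 1 `CN1CCC[C@H]1COc1cccnc1` gives 100%
compound 2 `CN1CCC[C@H]1COc1cccnc1Br` gives 12.3%
compound 3 `Cc1ccc(OC[C@@H]2CCCN2C)cn1` gives 54.4%

In an assay on K177 cells with Neuronal acetylcholine receptor; alpha4/beta2 (Homo sapiens) as the target (on this read-out lower numbers stand for smaller maximal responses and higher numbers for larger maximal responses), compound 3 stands second highest of the three numbers; compound 2 is the nearest to it and lies lower, while compound 1 is the furthest and lies higher, as a number 45.6 percentage points lower from compound 1 to compound 3 (beyond the scatter) shows. The step from compound 3 to compound 4 `CN1CCC[C@H]1COc1ccc(Cl)nc1` is chloro in place of methyl on an aromatic carbon: the chloro enters at the very place where the methyl leaves.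

Within the data shown here, two measured steps bear on this. Both start from compound 1 and add a single small group on an aromatic carbon of the shared core, and both lower the maximal response: a number 87.7 percentage points lower from compound 1 to compound 2 (beyond the scatter) for bromo, a number 45.6 percentage points lower from compound 1 to compound 3 (beyond the scatter) for methyl. Compound 4 carries a halogen, as compound 2 does, but at the place of the methyl of compound 3 rather than at the place of the bromo of compound 2. Since the data contain no case in which one small group at this place is replaced by another, the change is expected to shift this assay only modestly, if at all, from the value of compound 3, and the estimated step is a number 9.4 percentage points lower from compound 3 to compound 4 (within the scatter). Compound 4 is therefore expected to give about 45%, within a range from 20% to 75%.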

Compound 4, largest response reached (reported as maximum), in percent of the reference or control that the assay uses: 108%
Compound 4: middle estimate off by 63 percentage points, on the low side; measured number outside the range, above it.
By their numbers in this assay, from the lowest: compound 2; then compound 3; then compounds 1 and 4 (each within the scatter of the next).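

In this assay, a substituent on the aromatic carbon next to the ring nitrogen does not by itself lower the maximal response: the change from methyl to chloro gives a number 53.6 percentage points higher from compound 3 to compound 4 (beyond the scatter) and so separates two groups of one heavy atom each, neither with a hydrogen-bond donor or acceptor. Putting chloro in place of hydrogen gives a number 8 percentage points higher from compound 1 to compound 4 (within the scatter) and leaves compound 4 level with compound 1, so at this place the loss seen with methyl belongs to that group and not to substitution as such. Nothing measured here explains why methyl and chloro part so widely.

Going by these compounds, whether fluoro or bromo at this place would match chloro or fall towards methyl remains open, as does the effect of a larger group there, such as an amine, a methoxy group or a longer chain. The compounds shown also leave open whether chloro would fare any better than bromo at the place where compound 2 carries its bromo.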